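Removing One Methoxy Group: Expected Cell Tolerance

The source may hold more compounds than are shown below. What is called first, only, known or untested is meant among the compounds shown, and "the series" means these compounds.

Of the compounds shown here, two sharing the same core have been measured in a functional assay on A498 cells (Homo sapiens) for inhibition, read by sulforhodamine B assay, with a stated time of 48 h; a higher number here means that more compound is tolerated, a lower number that less compound is tolerated. Compound 1 `COc1ccc(-c2cc(/C=C/C(=O)c3ccc(N)cc3)[nH]n2)cc1` gives 15400 nM in this assay. Compound 2 `COc1cc(-c2cc(/C=C/C(=O)c3ccc(N)cc3)[nH]n2)cc(OC)c1OC`, which carries three methoxy groups on the same ring, gives 13400 nM. Compound 2 holds the lowest of the two numbers, yet its nearest neighbour, compound 1, lies within the usual scatter of such measurements, so the two values cannot be told apart.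

Compound 3 `COc1ccc(-c2cc(/C=C/C(=O)c3ccc(N)cc3)[nH]n2)cc1OC` has not yet been measured. It differs from compound 2 by one change: hydrogen in place of methoxy on an aromatic carbon. Going by the values given here, no step between measured compounds isolates this change. Because compound 1 with 15400 nM and compound 2 with 13400 nM sit so close together, the expected step is a 1.0-fold higher number from compound 2 to compound 3 (0.02 log units; within the scatter), with no direction beyond the scatter. Compound 3 is therefore estimated at 14000 nM, with a likely range from 6000 nM to 32000 nM.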

Compound 3, concentration lethal to 50% of the cells: 26200 nM
For compound 3 the middle estimate is 1.9-fold (0.27 log units) below the measured one; the range from low to high includes it.
By their numbers in this assay, from the lowest: compounds 2, 1 and 3 (each within the scatter of the next).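

In this assay, replacing the methoxy group with hydrogen on this aromatic carbon, ortho to a methoxy group and meta to a large group, gives a step that stays within the scatter (a 2.0-fold higher number from compound 2 to compound 3 (0.29 log units; within the scatter)). The reverse kind of change, methoxy in place of hydrogen on an aromatic carbon, also stays within the scatter (a 1.7-fold higher number from compound 1 to compound 3 (0.23 log units; within the scatter)). Going by these compounds alone, these are the first single-place comparisons, and neither shows that adding or removing one methoxy group changes the number measurably.

The compounds shown leave open whether a different group on this carbon, such as a hydroxyl, a fluorine atom or a longer alkoxy chain, would move the number beyond the scatter. Nothing further is available to help interpret these small steps.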